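The source may report more compounds than this note shows. Statements on the series, on what has been measured and on what is new or still open speak of the compounds shown alone.

The study measures cytotoxicity in a functional assay on KM12 cells (Homo sapiens) for inhibition, read by sulforhodamine B assay, with a stated time of 48 h; on this read-out higher numbers stand for lower toxicity in this test and lower numbers for higher toxicity in this test. Compound 1, `O=C(Nc1cccc(-n2cc(-c3ccncc3)c(-c3ccc(Cl)c(O)c3)n2)c1)Nc1cccc(C(F)(F)F)c1`, is the hydroxy-bearing member of the shared core; in this assay compound 1 reaches only a limit, > 32500 nM. Among the measured compounds shown here, compound 2, `COc1cc(-c2nn(-c3cccc(NC(=O)Nc4ccc(Cl)c(C(F)(F)F)c4)c3)cc2-c2ccncc2)ccc1Cl`, carries a methoxy group on the same ring and a chloro-trifluoromethylphenyl urea; in this assay compound 2 gives 14900 nM, the only true number among the two results. The other result, that of compound 1, is a limit (the limit of > 32500 nM in this assay, at which 1 of the 2 values shown sits).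

The piece now turns to compound 3, `O=C(Nc1cccc(-n2cc(-c3ccncc3)c(-c3ccc(Cl)c(O)c3)n2)c1)Nc1ccc(Cl)c(C(F)(F)F)c1`, which keeps the urea of compound 2 and differs from it by a single change: hydrogen in place of methyl on an oxygen on an aromatic ring. For the measured compounds named here, no measured pair in this set differs in exactly that place, so the size of the step can only be expected. The expectation for compound 3 leans on compound 1, whose result in this assay is a limit, > 32500 nM. On that basis the step is expected to run toward lower toxicity, a 1.7-fold higher number from compound 2 to compound 3 (0.22 log units; within the scatter), and compound 3 is expected to sit near 25000 nM, between 10000 nM and 45000 nM.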

Compound 3, concentration lethal to 50% of the cells: 17400 nM
Compound 3: the middle estimate sits 1.4-fold (0.16 log units) above what was measured; measured number inside the range.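

Among the compounds shown here, with the chloro-trifluoromethylphenyl urea held fixed, the change from 4-chloro-3-methoxyphenyl to 4-chloro-3-hydroxyphenyl gives the first direct reading at this position in this assay, and that reading is a 1.2-fold higher number from compound 2 to compound 3 (0.07 log units; within the scatter), so the two compounds cannot be told apart here and methyl or hydrogen on this oxygen makes no measurable difference in this pair. With the hydroxy group held fixed instead, chloro in place of hydrogen on an aromatic carbon of the urea part gives an at least 1.8-fold lower number from compound 1 to compound 3 (0.27 log units; that floor lies within the scatter), which is a floor and not a true size, and that floor does not go beyond the usual scatter. Compound 1 gives only a limit in this assay, so one end of this step is not a number: the limit of > 32500 nM in this assay, at which 1 of the 3 values shown sits.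

The compounds shown leave open whether a different group on this oxygen, such as an ethyl chain, or an amine in place of the hydroxy, would separate from the methoxy and hydroxy pair in this assay. They also leave open the true size of the chloro step, and whether that step would read the same with methoxy in place of hydroxy.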